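The source may hold more compounds than are shown below. What is called first, only, known or untested is meant among the compounds shown, and "the series" means these compounds.

Of the compounds shown here, three sharing one core have been measured in a functional assay on HEK293 cells for agonist activity at D(4) dopamine receptor (Homo sapiens), read by FLIPR; on this read-out lower numbers stand for smaller maximal responses and higher numbers for larger maximal responses. Compound 1 `O=C(NCN1CCC(c2cccc[n+]2[O-])CC1)c1ccccc1` gives 63%. Compound 2 `O=C(CN1CCC(c2cccc[n+]2[O-])CC1)Nc1cccc(F)c1` gives 70%, and compound 3 `CCOc1cccc(C(=O)NCN2CCC(c3cccc[n+]3[O-])CC2)c1` gives 54%. On these numbers compound 1 stands second of the three, yet both neighbours lie within the scatter of it, so no order among them can be claimed. Among the measured compounds shown here, only one step between compounds differing in a single place is available: a number 9 percentage points lower from compound 1 to compound 3 (within the scatter), which does not reach beyond the scatter.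

Compound 4 `Cc1cc(C)cc(C(=O)NCN2CCC(c3cccc[n+]3[O-])CC2)c1` has not yet been measured. It differs from compound 1 in one place: 3,5-dimethylphenyl in place of phenyl on a carbonyl carbon. For the measured compounds named here, the only measured change on the same aromatic ring is the one from compound 1 to compound 3, and since a number 9 percentage points lower from compound 1 to compound 3 (within the scatter) stayed within the scatter, a change of similar size is expected here, with no direction that can be trusted. The step that this estimate means, a number 5 percentage points lower from compound 1 to compound 4 (within the scatter), is expected to remain within the scatter. Compound 4 is therefore expected to reach about 58% in this assay, with a range from 42% to 74%.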

Compound 4, largest response reached (reported as efficacy), in percent of the reference or control that the assay uses: 56%
Beside the measured number, compound 4's estimate is 2 percentage points above it; low and high end bracket the measured number.
By their numbers in this assay, from the lowest: compounds 3, 4, 1 and 2 (each within the scatter of the next, the first and the last beyond it).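

Placing 3,5-dimethylphenyl in place of phenyl on the carbonyl carbon gives, in this assay, a number 7 percentage points lower from compound 1 to compound 4 (within the scatter), so a group of 8 heavy atoms in place of 6 at this position produces no step that can be told from the scatter. Before this result, the only change on this ring was ethoxy, with a number 9 percentage points lower from compound 1 to compound 3 (within the scatter); now two different changes on the ring both stay within the scatter of compound 1, and neither listed step goes against this. No measurement is available that would explain this result.

Going by these compounds, it remains open whether a different kind of group on this ring, such as an amine or a carboxylic acid, would take the response beyond the scatter. On these data alone, it is equally open what a longer chain in place of the phenyl would do.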